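Swapping a phenyl for a methyl-benzoxazole on the pyrrolidinone scaffold

A few compounds are considered here, and "the series" means these few. Any claim that something is new, unique, unknown or untested is made for them only; others in the source may bear on it.

Measured so far:
compound 1, `O=C(O)CCCSCCN1C(=O)CC[C@@H]1/C=C/[C@@H](O)Cc1cccc(-c2ccc3[nH]ccc3c2)c1`: 0.28 nM
compound 2, `O=C(O)c1csc(SCCN2C(=O)CC[C@@H]2/C=C/[C@@H](O)Cc2cccc(-c3ccccc3)c2)n1`: 0.94 nM

Both compounds were tested in an assay on CHO cells for displacement of a labelled ligand from prostaglandin E2 receptor EP4 subtype (Mus musculus), read by scintillation counting, with a stated time of 60 min; on this read-out lower numbers stand for stronger inhibition and higher numbers for weaker inhibition. Compound 1 gives 0.28 nM, while compound 2 gives 0.94 nM, the higher of the two numbers; the gap between them lies beyond the usual scatter, so compound 2 is the weaker binder of this pair. The two differ in more than one place, their acid-bearing chains as well as the aryl group, so no single change can be read from that comparison.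

Compound 3, `Cc1cccc2oc(-c3cccc(C[C@H](O)/C=C/[C@H]4CCC(=O)N4CCSc4nc(C(=O)O)cs4)c3)nc12`, has not yet been measured. It keeps the whole of compound 2 apart from one change: 4-methyl-1,3-benzoxazol-2-yl in place of phenyl on an aromatic carbon. Compound 1 carries a bicyclic aromatic group at the corresponding point and sits at 0.28 nM, which suggests that a larger two-ring group is at least tolerated there. On that basis the step is expected to be modest, most likely toward a lower number, and might also stay within the scatter.

Compound 3 is therefore expected to give 0.6 nM, with a range from 0.2 nM to 2 nM, which would be a step of a 1.6-fold lower number from compound 2 to compound 3 (0.19 log units; within the scatter).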

Compound 3, inhibition constant: 0.21 nM
Compound 3: middle estimate off by 2.9-fold (0.46 log units), on the high side, and the stated range covers the measured number.
By their numbers in this assay, from the lowest: compounds 3 and 1 (each within the scatter of the next); then compound 2.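

In this assay, putting 4-methyl-1,3-benzoxazol-2-yl in place of phenyl on this aromatic carbon gives a 4.5-fold lower number from compound 2 to compound 3 (0.65 log units; beyond the scatter). Within the data shown here, this is the first clean reading at this position: compound 1 and compound 2 differ in more than one place, whereas here the rest of the molecule stays fixed, and the step shows that binding responds to the group at this point and that the larger two-ring group is more than merely tolerated. The change alters several things at once, however, adding a second ring, ring nitrogen and oxygen atoms, 2 hydrogen-bond acceptors and a methyl group, and nothing available here shows which of these accounts for the step.

The compounds shown leave open whether the methyl group contributes, a question that the unsubstituted 1,3-benzoxazol-2-yl group would address, and whether the ring nitrogen matters, which a benzofuran-2-yl group would test. Among these compounds, they also leave open whether 4-methyl-1,3-benzoxazol-2-yl would give a similar step on the other acid-bearing chain, the one carried by compound 1.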